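A Pyridyl Urea Tail on an Oxygen-Linked Scaffold

The source may report more compounds than this note shows. Statements on the series, on what has been measured and on what is new or still open speak of the compounds shown alone.

Within the data shown here, compound 3 `Cc1cccc(NC(=O)Nc2ccc(Oc3ncnc4[nH]ncc34)cc2)c1C` is the only compound in this set with an actual number: in an assay on isolated protein for inhibition of vascular endothelial growth factor receptor 2 (Danio rerio), read by fluorescence and microscopy, with a stated time of 33 h (a higher number here means a weaker inhibitor, a lower number a stronger inhibitor), compound 3 gives 98800 nM. Compound 1 `Cc1cccc(NC(=O)Nc2ccc(Nc3ncnc4[nH]ncc34)cc2)c1C` is reported only as a limit of this assay, > 100000 nM. Compound 2 `O=C(Nc1ccc(Nc2ncnc3[nH]ncc23)cc1)Nc1ccc(C(F)(F)F)cc1` likewise reaches only a limit of this assay, > 100000 nM. The step that the two limits leave unreadable from compound 1 to compound 2 thus cannot be read, since both ends rest at the limit of > 100000 nM in this assay, at which 2 of the 3 values shown sit. Compound 4 `O=C(Nc1ccc(Oc2ncnc3[nH]ncc23)cc1)Nc1cccnc1` differs from compound 3 by pyridin-3-yl in place of 2,3-dimethylphenyl on an amide-type nitrogen. Among the measured compounds shown here, no measured step carries this exact exchange; the one measured step, from compound 1 to compound 2, also swaps the aryl group on the same amide-type nitrogen, but its size is hidden by limits. Compound 3 already stands close to the limit at which the other two compounds sit. The change to compound 4 is therefore expected to move it by a 1.0-fold higher number from compound 3 to compound 4 (0.01 log units; within the scatter), in no clear direction beyond the scatter. Compound 4 is estimated at 100000 nM, with a range from 30000 nM to 300000 nM.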

Compound 4, half-maximal inhibitory concentration: > 100000 nM
Compound 4 was reported as a limit (the forecaster's own chance of this, stated with the estimate: 60%); the middle value sits exactly at the limit.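

In this assay, among these compounds, this is the first step at the amide-type nitrogen with a number at one end, and it gives an at least 1.0-fold higher number from compound 3 to compound 4 (0.00 log units; that floor lies within the scatter). Compound 4 is reported only as a limit, so that step is a floor and not a size, because the reading stops at the end of the assay's range: the limit of > 100000 nM in this assay, at which 3 of the 4 values shown sit. Exchanging 2,3-dimethylphenyl for pyridin-3-yl therefore adds a ring nitrogen and a hydrogen-bond acceptor at this position without producing a value clear of that limit.

On these data alone, how far the true value of compound 4 lies beyond the limit remains open. So does whether a phenyl ring carrying an amine or a carboxylic acid, or a longer chain, on this amide-type nitrogen would give a number well inside the range of the assay.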